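Replacing methoxyphenyl with a methyl-trifluoromethyl ring

This account rests on a few compounds, and the source may have more. Where it says the series, first, only, none or still open, it means among the compounds named here.

Compound 1, `CCCc1ccc(C(=O)Nc2cccc(NC(=O)COc3ccc4c(=O)ccoc4c3)c2)cc1`: 143 nM
Compound 2, `COc1ccc(C(=O)Nc2cccc(NC(=O)COc3ccc4c(=O)ccoc4c3)c2)cc1`: 18 nM

For the measured compounds named here, in an assay on isolated protein for inhibition of Rho-associated protein kinase 1 (Homo sapiens), read by scintillation counting, radiometric assay and 33P incorporation, with a stated time of 40 min, in the presence of a further agent that is not named here (a higher number here means a weaker inhibitor, a lower number a stronger inhibitor), compound 2 gives the lowest of the two numbers so far; its nearest neighbour is compound 1, which gives 143 nM in this assay. Going by the values given here, the one step between them, a 7.9-fold lower number from compound 1 to compound 2 (0.90 log units; beyond the scatter), is the only comparison available, and it shows that a group bearing one hydrogen-bond acceptor on that ring gives the stronger inhibitor than a plain propyl chain.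

Compound 3, `Cc1cc(C(=O)Nc2cccc(NC(=O)COc3ccc4c(=O)ccoc4c3)c2)ccc1C(F)(F)F`, has not yet been measured. It differs from compound 2 by a group of 11 heavy atoms (8 carbon, 3 fluorine; one six-membered aromatic ring of carbon only) in place of a group of 8 heavy atoms (7 carbon, 1 oxygen; one six-membered aromatic ring of carbon only), on a carbonyl carbon. The entering group, like the propyl of compound 1, carries no hydrogen-bond acceptor, so the step of a 7.9-fold lower number from compound 1 to compound 2 (0.90 log units; beyond the scatter) is the one that bears on it, and it suggests a move back toward higher numbers. Because a 7.9-fold lower number from compound 1 to compound 2 (0.90 log units; beyond the scatter) was beyond the scatter, the step is expected as a 5.0-fold higher number from compound 2 to compound 3 (0.70 log units; beyond the scatter) in this assay. Compound 3 is therefore estimated at 90 nM in this assay, within a range from 30 nM to 300 nM.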

Compound 3, half-maximal inhibitory concentration: 460 nM
Compound 3: middle estimate off by 5.1-fold (0.71 log units), on the low side; measured number outside the range, above it.
By their numbers in this assay, from the lowest: compound 2; then compound 1; then compound 3.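

In this assay, the methyl-trifluoromethyl ring proved far less favourable at this position on the carbonyl carbon than the 4-methoxyphenyl group, with a 26-fold higher number from compound 2 to compound 3 (1.41 log units; beyond the scatter). It also fell short of the propyl-bearing ring, with a 3.2-fold higher number from compound 1 to compound 3 (0.51 log units; beyond the scatter), so the two groups without a hydrogen-bond acceptor do not give the same number, and the absence of an acceptor cannot by itself account for the values at this position. No supporting measurement is available to explain why the number rises with this change.

Compound 3 carries its methyl and trifluoromethyl groups together, so the compounds shown leave open how much of the step from the 4-methoxyphenyl group belongs to either one, a question that a ring bearing only trifluoromethyl or only methyl would address. They also leave open whether the gain seen with the 4-methoxyphenyl group extends to other oxygen-bearing groups on this ring, such as ethoxy or a carboxylic acid, or to a nitrogen-bearing group such as an amine.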